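Swapping the Benzyl Substituent on an Acetate Ester

The source may report more compounds than this note shows. Statements on the series, on what has been measured and on what is new or still open speak of the compounds shown alone.

Of the compounds shown here, three have been measured in an ADME assay on L6 cells (Rattus norvegicus) for cytotoxicity, read by resazurin assay, with a stated time of 70 h; on this read-out lower numbers stand for stronger inhibition and higher numbers for weaker inhibition. Compound 1 `CC1=CC(C)(C)N(Cc2cccc(C(F)(F)F)c2)c2ccc(OCc3cccc(C(F)(F)F)c3)cc21` gives only a limit, > 180000 nM, and not a number. Compound 2 `COc1ccc(CN2c3ccc(O)cc3C(C)=CC2(C)C)cc1` gives 6200 nM. Compound 3 `CC(=O)Oc1ccc2c(c1)C(C)=CC(C)(C)N2Cc1ccc(C#N)cc1` gives 29000 nM, the higher of the two actual numbers and clearly separated from compound 2.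

The next structure, compound 4 `CC(=O)Oc1ccc2c(c1)C(C)=CC(C)(C)N2Cc1cccc(Cl)c1`, has 3-chlorophenyl in place of 4-cyanophenyl on a saturated chain carbon bound to a nitrogen on an aromatic ring in a ring. For the measured compounds named here, no measured pair of compounds isolates a change of this kind, so the expectation has little to rest on beyond compound 3 itself, at 29000 nM, as the starting point. No step beyond the scatter is expected in this assay, with only a slight lean toward a lower number. The expected step of a 1.5-fold lower number from compound 3 to compound 4 (0.16 log units; within the scatter) therefore remains small. For compound 4 the estimate is 20000 nM, with an expected range of 7000 nM to 60000 nM.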

Compound 4, half-maximal inhibitory concentration: 29000 nM
For compound 4 the middle estimate is 1.5-fold (0.16 log units) below the measured one; the range from low to high includes it.
By their numbers in this assay, from the lowest: compound 2; then compounds 3 and 4 (each within the scatter of the next). At a limit, above all of these: compound 1.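

For the compounds shown here, this step is the first to isolate a single place. In this assay, 3-chlorophenyl in place of 4-cyanophenyl on a saturated chain carbon bound to a nitrogen on an aromatic ring in a ring gives no change at the digits printed from compound 3 to compound 4 (within the scatter) with the acetate ester kept. At this place, then, the read-out does not separate the two rings, although the triple bond and the hydrogen-bond acceptor of the leaving group are gone. Nothing measured on these compounds bears on why the number holds still.

As far as these compounds go, only these two groups are compared here on the acetate ester, so it remains open whether an amine or a carboxylic acid on the ring would shift the number. From the compounds shown here alone, it also remains open whether 4-chlorophenyl or 3-cyanophenyl would match these two.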